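Amine ring swaps on the shared core: a third variant

This account rests on a few compounds, and the source may have more. Where it says the series, first, only, none or still open, it means among the compounds named here.

Compound 2 `Cn1c(=O)n(Cc2ccccc2C#N)c2c(N3CCCCC(N)C3)ccnc21` sits at a limit of an assay on isolated protein for inhibition of Dipeptidyl peptidase 9 (Homo sapiens), read by luminescence, with a stated time of 15 min (on this read-out lower numbers stand for stronger inhibition and higher numbers for weaker inhibition), giving > 100000 nM. Compound 1 `Cn1c(=O)n(Cc2ccccc2C#N)c2c(N3CC[C@@H](N)C3)ccnc21` likewise returns only the limit > 100000 nM. The step that the two limits leave unreadable from compound 1 to compound 2 is therefore unreadable, and the limit of > 100000 nM in this assay, at which 2 of the 2 values shown sit, is all the two values show. Compound 3 `CC(=O)N[C@@H]1CCCN(c2ccnc3c2n(Cc2ccccc2C#N)c(=O)n3C)C1` differs from compound 2 by 3-acetamidopiperidin-1-yl in place of 3-aminoazepan-1-yl on an aromatic carbon. Among the measured compounds shown here, no measured step reads on this exchange, so no direction of change can be expected beyond the scatter. For compound 3 the expected value is 100000 nM, between 20000 nM and 300000 nM. The expected step is a number no higher from compound 2 to compound 3 (the limit leaves the size open), most likely again reported as a limit.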

Compound 3, half-maximal inhibitory concentration: > 100000 nM
Compound 3: only a limit was reported; the forecaster's own chance of this, stated with the estimate: 75%; the middle value sits exactly at the limit.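

Compound 3 returns > 100000 nM, which is a limit. No step among compound 1, compound 2 and compound 3 can be read, and the values show only this: the limit of > 100000 nM in this assay, at which 3 of the 3 values shown sit.

The compounds shown leave open whether any amine ring on the shared core would give a readable value.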